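Dichlorophenyl variant of the saturated-chain amide

The compounds below may be only part of what the source reports. "The series", "measured", "known", "first", "only" and "open" are said of these compounds alone.

Measured compounds in an assay on mitochondria (strain Sprague-Dawley) for inhibition of Amine oxidase [flavin-containing] B (Rattus norvegicus), read by fluorescence and Amplex Red, with stated times of 30 min and 45 min; on this read-out higher numbers stand for weaker inhibition and lower numbers for stronger inhibition:
compound 1 `O=C(CCc1ccccc1)Nc1nc2ccccc2c(=O)s1` gives 42.7 nM
compound 2 `COc1cccc(/C=C/C(=O)Nc2nc3ccccc3c(=O)s2)c1` gives 281 nM
compound 3 `O=C(/C=C/c1cccc(Cl)c1)Nc1nc2ccccc2c(=O)s1` gives 815 nM

Compound 1 gives the lowest number of the three in this assay; compound 2 and compound 3 both sit beyond the scatter above it. Compound 4 `O=C(CCc1ccc(Cl)c(Cl)c1)Nc1nc2ccccc2c(=O)s1` differs from compound 1 by 3,4-dichlorophenyl in place of phenyl on a saturated chain carbon, two bonds along the chain from a carbonyl carbon. Within the data shown here, the only step recorded on a single change is a 2.9-fold higher number from compound 2 to compound 3 (0.46 log units; beyond the scatter), made on the unsaturated chain and swapping one substituent for another rather than adding chlorine to a bare phenyl, so it bears on the present change only loosely. Among the measured compounds shown here, no measured step sets a direction for compound 4, so the expected step of a 1.2-fold higher number from compound 1 to compound 4 (0.07 log units; within the scatter) is small and may fall within the scatter. Compound 4 is therefore estimated at 50 nM, with a range of 15 nM to 170 nM.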

Compound 4, half-maximal inhibitory concentration: > 10000 nM
Compound 4: only a limit was reported; the forecaster's own chance of this, stated with the estimate: 2%; middle value at least 200-fold (2.30 log units) away from the limit.
By their numbers in this assay, from the lowest: compound 1; then compound 2; then compound 3. At a limit, above all of these: compound 4.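

In this assay, 3,4-dichlorophenyl in place of phenyl on the saturated chain gives an at least 230-fold higher number from compound 1 to compound 4 (2.36 log units; beyond the scatter), so this position does not accept every substituted phenyl. Among these compounds, compound 4 gives > 10000 nM, which is a limit of the assay and not a number, so the step has no upper bound: the limit of > 10000 nM in this assay, at which 1 of the 4 values shown sits. The only earlier step, a 2.9-fold higher number from compound 2 to compound 3 (0.46 log units; beyond the scatter), gave no sign of a change this large.

As far as these compounds go, whether a single chlorine on the phenyl of the saturated chain is enough for this loss remains open. The effect of a methoxy or a fluorine there is also unknown.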